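The source may hold more compounds than are shown below. What is called first, only, known or untested is meant among the compounds shown, and "the series" means these compounds.

Series notes. Compound 3 `NS(=O)(=O)c1ccc(CNc2nc(Nc3cccc(NC(=O)N4CCCC4)c3)ncc2C2CC2)cc1` gives only a limit: in an assay on HEK293 cells for displacement of a labelled ligand from MAP/microtubule affinity-regulating kinase 3 (Homo sapiens), read by NanoBRET (on this read-out higher numbers stand for weaker inhibition and lower numbers for stronger inhibition), compound 3 reads > 10000 nM, which is the assay limit and not a number. The same limit, (the limit of > 10000 nM in this assay, at which 2 of the 3 values shown sit), also holds for compound 1 `O=C(NCCCNc1ccnc(Nc2cccc(NC(=O)N3CCCC3)c2)n1)C1CCC1`, which in this assay gives > 10000 nM. Compound 2 `O=C(NCCCNc1nc(Nc2cccc(NC(=O)N3CCCC3)c2)ncc1Br)C1CCC1` in this assay gives 137 nM. Going by the values given here, the single measured step, an at least 72-fold lower number from compound 1 to compound 2 (1.86 log units; beyond the scatter), is large and beyond the scatter.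

Compound 4 `O=C(NCCCNc1nc(Nc2cccc(NC(=O)N3CCCC3)c2)ncc1C1CC1)C1CCC1` differs from compound 3 by 2-((cyclobutylcarbonyl)amino)ethyl in place of 4-sulfamoylphenyl on a saturated chain carbon bound to a nitrogen on an aromatic ring. Among the compounds with values here, no measured step covers this exchange directly. The step from compound 1 to compound 2 alters a different part of the shared core and bears on compound 4 only indirectly: compound 4 carries the same chain as compound 2, with a cyclopropyl on the aromatic carbon where compound 2 carries bromo and compound 1 carries hydrogen. With that chain compound 2 reaches 137 nM. With the cyclopropyl and the other chain, compound 3 stays at the limit.

Compound 4 is expected to leave the limit, a step estimated at an at least 25-fold lower number from compound 3 to compound 4 (1.39 log units; beyond the scatter), though its true size cannot be fixed from a starting limit. The estimate for compound 4 in this assay is 400 nM, with an expected range from 60 nM to 4000 nM.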

Compound 4, half-maximal inhibitory concentration: 2000 nM
Compound 4: middle estimate off by 5.0-fold (0.70 log units), on the low side; the measured number falls inside the stated range.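

With the 3-((cyclobutylcarbonyl)amino)propyl chain held fixed in this assay, cyclopropyl on the aromatic carbon is clearly not equivalent to bromo (a 15-fold higher number from compound 2 to compound 4 (1.16 log units; beyond the scatter)), so this position responds to more than the mere presence of a group. Cyclopropyl still improves on hydrogen with the same chain (an at least 5.0-fold lower number from compound 1 to compound 4 (0.69 log units; beyond the scatter)), which places these three compounds in the order bromo, then cyclopropyl, then hydrogen, with hydrogen fixed only by a limit. With cyclopropyl held fixed, the exchange on the saturated chain carbon bound to a nitrogen on an aromatic ring also matters (an at least 5.0-fold lower number from compound 3 to compound 4 (0.69 log units; beyond the scatter)), but this step and the one from hydrogen both start from a limit and are bounds only: the limit of > 10000 nM in this assay, at which 2 of the 4 values shown sit.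

Going by these compounds, whether chloro or methyl on the aromatic carbon would read closer to bromo or to cyclopropyl stays open, as does the true size of the two bounded steps. Also open, on these data alone, are how the 4-sulfamoylbenzyl group reads with bromo on that carbon, and whether an amine or a carboxylic acid in place of the cyclobutyl group keeps the value of compound 4.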